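Notes on a (methoxycarbonyl)amino analogue of compound 1

The source may hold more compounds than are shown below. What is called first, only, known or untested is meant among the compounds shown, and "the series" means these compounds.

Measured in a functional assay for antagonist activity at melanin-concentrating hormone receptor 1 (Homo sapiens), read by cAMP accumulation (on this read-out higher numbers stand for an effect only at larger amounts of compound and lower numbers for an effect already at smaller amounts), so far:
compound 1, `CO[C@@H]1CN(CC2Cc3ccccc3C2)CC[C@H]1n1c(C)nc2cc(C)ccc21`, gives 69 nM
compound 2, `CO[C@@H]1CN(C[C@@H]2Cc3ccc(NC(=O)C(C)C)cc3C2)CC[C@H]1n1c(C)nc2cc(C)ccc21`, gives 40 nM
compound 3, `CO[C@@H]1CN(C[C@H]2Cc3ccc(C#N)cc3C2)CC[C@H]1n1c(C(C)(C)O)nc2cc(C)ccc21`, gives 17 nM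

Compound 1 carries the highest of the three numbers; its nearest neighbour is compound 2, a gap within the scatter, and compound 3 sits furthest from it, a gap beyond the scatter. Compound 4, `COC(=O)Nc1ccc2c(c1)C[C@@H](CN1CC[C@@H](n3c(C)nc4cc(C)ccc43)[C@H](OC)C1)C2`, is not yet measured. It differs from compound 1 in one place: (methoxycarbonyl)amino in place of hydrogen on an aromatic carbon. For the measured compounds named here, the only measured step that bears on this change is the one from compound 1 to compound 2, which likewise puts a substituent of related kind in place of hydrogen on an aromatic carbon of the same ring: a 1.7-fold lower number from compound 1 to compound 2 (0.24 log units; within the scatter). Compound 3 differs from compound 1 in more than one place, so its value is no guide to this single change. The expectation for compound 4 in this assay is therefore at most a small downward shift from compound 1, not clearly beyond the scatter: a 1.5-fold lower number from compound 1 to compound 4 (0.19 log units; within the scatter). Compound 4 is estimated at 45 nM, with a range from 20 nM to 110 nM.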

Compound 4, half-maximal effective concentration: 20 nM
Beside the measured number, compound 4's estimate is 2.3-fold (0.35 log units) above it; the measured number falls inside the stated range.
By their numbers in this assay, from the lowest: compounds 3, 4, 2 and 1 (each within the scatter of the next, the first and the last beyond it).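

In this assay the step of a 3.5-fold lower number from compound 1 to compound 4 (0.54 log units; beyond the scatter) is a single change on this aromatic carbon that clears the scatter, though only modestly, whereas the step of a 1.7-fold lower number from compound 1 to compound 2 (0.24 log units; within the scatter) does not. Substitution at this place can therefore lower the number measurably from that of the unsubstituted compound 1. Compound 2 and compound 4 remain within the scatter of each other, so (methoxycarbonyl)amino and (isopropylcarbonyl)amino are not separated here. No measurement shown accounts for the step.

Open, going by these compounds, is whether a free amine, a carboxylic acid or a longer alkoxycarbonylamino chain on the same aromatic carbon would move the number further, or reverse the step. Also open, on these data alone, is whether (methoxycarbonyl)amino acts alike on cores other than that of compound 1.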